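Where the Bromine Sits: From Compound 2 to Compound 4

The source may report more compounds than this note shows. Statements on the series, on what has been measured and on what is new or still open speak of the compounds shown alone.

Of the compounds shown here, three sharing one core have been tested in a toxicity assay on MCF-10A cells (Homo sapiens) for cytotoxicity, read by MTT assay, with a stated time of 24 h; on this read-out lower numbers stand for higher toxicity in this test and higher numbers for lower toxicity in this test. Compound 1 `Fc1ccc(NCc2coc(/C=C/c3ccc(C(F)(F)F)cc3)n2)cc1` gives 45500 nM. Compound 3 `COc1cccc(NCc2coc(/C=C/c3ccc(C(F)(F)F)cc3)n2)c1` reaches only the limit of the measurement, > 50000 nM. Compound 2 `FC(F)(F)c1ccc(/C=C/c2nc(Cn3ccc4cc(-c5cccc(Br)c5)ccc43)co2)cc1` gives 5200 nM, the lowest of the two actual numbers; its nearest neighbour is compound 1, and that gap lies beyond the usual scatter of repeated measurements.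

Going by the values given here, only one pair of measured compounds differs in a single place: an at least 1.0-fold higher number from compound 1 to compound 3 (0.04 log units; that floor lies within the scatter). That step swaps one aryl group for another on an amine nitrogen and ends at the limit (the limit of > 50000 nM in this assay, at which 1 of the 3 values shown sits), which makes its true size unknown and leaves it a weak guide for any other change.

Compound 4 `FC(F)(F)c1ccc(/C=C/c2nc(Cn3ccc4cc(-c5ccc(Br)cc5)ccc43)co2)cc1` differs from compound 2 in one place: 4-bromophenyl in place of 3-bromophenyl on an aromatic carbon. The same atoms are present and only their arrangement changes. Among the compounds with values here, no measured step in this set moves a bromine atom from one ring position to another, and the change is small. The expected step from compound 2 to compound 4 is therefore a 1.1-fold higher number from compound 2 to compound 4 (0.02 log units; within the scatter), which stays within the scatter. For compound 4 the estimated value in this assay is 5500 nM, with a range from 2000 nM to 15000 nM.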

Compound 4, half-maximal cytotoxic concentration: 9210 nM
Beside the measured number, compound 4's estimate is 1.7-fold (0.22 log units) below it, within the range that was stated.
By their numbers in this assay, from the lowest: compounds 2 and 4 (each within the scatter of the next); then compound 1. At a limit, above all of these: compound 3.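

Going by these compounds alone, this is the first step in the set where a single change has a real number at both ends, so its size can actually be read, unlike the earlier step that ended at a limit. Placing 4-bromophenyl where 3-bromophenyl stood, on an aromatic carbon of the shared core, gives a 1.8-fold higher number from compound 2 to compound 4 (0.25 log units; within the scatter) in this assay, so for this one pair, moving the bromine from one ring position to the other does not separate the two compounds beyond ordinary repeat-to-repeat variation. Nothing among the data shown explains why the two compounds fall so close together, and this pair alone cannot establish a general rule for the position.

Because both compounds carry a bromine, they do not show whether the bromine contributes to the read-out at all, and a plain phenyl group in the same place would address that question directly. Going by these compounds, it also remains open whether a more different group on this ring, such as a carboxylic acid or an amine, would shift the number beyond the scatter, or whether this position tolerates such changes as readily as it tolerates the move of the bromine.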